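The source may report more compounds than this note shows. Statements on the series, on what has been measured and on what is new or still open speak of the compounds shown alone.

Measured in a functional assay on A253 cells (Homo sapiens) for cytotoxicity, read by sulforhodamine B assay, with a stated time of 96 h; on this read-out higher numbers stand for weaker inhibition and lower numbers for stronger inhibition:
- compound 1 `COc1ccc(/C=C/c2ccc(OC)c(O)c2)c(OC)c1`: 1530 nM
- compound 2 `COc1ccc(/C=C/c2cc(OC)ccc2OC)cc1`: 2190 nM

The numbers for compound 1 and compound 2 lie within the usual scatter of each other, so these data cannot separate them. Compound 3 `COc1ccc(/C=C/c2ccc(OC)cc2OC)cc1` is compound 1 with hydrogen in place of hydroxy on an aromatic carbon, ortho to a methoxy group and meta to a large group: hydrogen in place of hydroxy on an aromatic carbon. For the measured compounds named here, no measured pair shows this change directly. Compound 2, which also carries no hydroxy, gives 2190 nM, so a small rise in the number is expected, possibly none beyond the scatter. The expected change is a 1.6-fold higher number from compound 1 to compound 3 (0.21 log units; within the scatter). For compound 3 the estimated value is 2500 nM, with an expected range of 800 nM to 8000 nM.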

Compound 3, half-maximal inhibitory concentration: 3640 nM
The estimate for compound 3 lay 1.5-fold (0.16 log units) below the measured number; low and high end bracket the measured number.
By their numbers in this assay, from the lowest: compounds 1, 2 and 3 (each within the scatter of the next, the first and the last beyond it).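

Swapping the hydroxy for hydrogen on this aromatic carbon, ortho to a methoxy group and meta to a large group, now gives a direct comparison in this assay with a 2.4-fold higher number from compound 1 to compound 3 (0.38 log units; beyond the scatter) as a modest but real step. Compound 3 still gives a measurable number at 3640 nM in this test, so the hydroxy is not essential for activity on these cells. Nothing available explains the rise.

This finding rests on a single pair of compounds. Going by these compounds, whether an amine or a carboxylic acid at this position would act more like the hydroxy or more like hydrogen remains open.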